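Compound 3: dimethylamino in place of piperidin-1-yl

The compounds below may be only part of what the source reports. "The series", "measured", "known", "first", "only" and "open" are said of these compounds alone.

Values so far in a physicochemical assay for lipophilicity, read by HPLC, measured as octanol-water partition; on this read-out higher numbers stand for higher lipophilicity and lower numbers for lower lipophilicity
compound 1 (`CN(C)C1=NN(c2ccccc2)CN(c2ccccc2Cl)C1=O`): 3.6
compound 2 (`O=C1C(N2CCCCC2)=NN(c2ccc(Cl)cc2)CN1c1ccccc1Cl`): 5

Of these two measured compounds, compound 2 stands highest at 5 in this assay. Compound 1 lies lower at 3.6, and the gap between them is beyond the scatter.

Compound 3 (`CN(C)C1=NN(c2ccc(Cl)cc2)CN(c2ccccc2Cl)C1=O`) has not yet been measured. It departs from compound 2 in one place: dimethylamino in place of piperidin-1-yl on a carbon with a double bond to nitrogen. For the measured compounds named here, no measured pair isolates this change, as compound 1 and compound 2 differ in more than one place. A step down beyond the scatter is still expected. That expectation rests on compound 1, which carries dimethylamino and reads 3.6, set against compound 2, which carries piperidin-1-yl and reads 5. The expected size of the change is a number 0.80 log units lower from compound 2 to compound 3 (beyond the scatter). For compound 3 the estimated value is 4.2, with an expected range from 3.8 to 4.7.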

Compound 3, partition coefficient: 4.2
Estimate against measurement, compound 3: no gap at the digits printed, and the stated range covers the measured number.
By their numbers in this assay, from the lowest: compound 1; then compound 3; then compound 2.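

Compound 3 separates two changes that were mixed between compound 1 and compound 2. In this assay, with the 4-chlorophenyl group held fixed, dimethylamino in place of piperidin-1-yl on the carbon with a double bond to nitrogen now stands alone and gives a number 0.80 log units lower from compound 2 to compound 3 (beyond the scatter), while with dimethylamino held fixed, chloro in place of hydrogen on an aromatic carbon gives a number 0.60 log units higher from compound 1 to compound 3 (beyond the scatter), so each single change carries a step of its own beyond the scatter. No measurement shown offers an explanation for either step.

The compounds shown leave open how other groups would read on the same carbon, such as morpholin-4-yl, with an oxygen in the six-membered ring, diethylamino, or a plain amine, and so whether the reading there follows the count of carbon atoms in the group or the presence of a ring. They also leave open whether the step between piperidin-1-yl and dimethylamino keeps its size on a phenyl group without the chloro, and how fluoro or methoxy would compare with chloro on that aromatic carbon.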